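Swapping an isopropyl for a phenoxy on an inactive triazole isomer

The source may hold more compounds than are shown below. What is called first, only, known or untested is meant among the compounds shown, and "the series" means these compounds.

Three compounds from a set built on a shared uracil-sugar core have been tested in an ADME assay on CCRF-CEM cells (Homo sapiens) for cytotoxicity, read by cell counting, with a stated time of 3 days; on this read-out lower numbers stand for stronger inhibition and higher numbers for weaker inhibition. Compound 1 `O=c1[nH]c(=O)n([C@H]2C[C@H](O)[C@@H](CO)O2)cc1-c1cn(-c2c(F)cccc2F)nn1` gives 1500 nM in this assay. Compound 2 `CC(C)c1ccc(-n2cc(-c3cn([C@H]4C[C@H](O)[C@@H](CO)O4)c(=O)[nH]c3=O)nn2)cc1` gives 22000 nM, and the step of a 15-fold higher number from compound 1 to compound 2 (1.17 log units; beyond the scatter) shows a large loss of potency. Compound 3 `CC(C)c1ccc(-n2nncc2-c2cn([C@H]3C[C@H](O)[C@@H](CO)O3)c(=O)[nH]c2=O)cc1` carries the same isopropylphenyl group as compound 2 but joined to the triazole ring in a different arrangement; in this assay compound 3 gives only a limit, > 200000 nM, so its true potency is weaker than the assay can resolve, and the limit of > 200000 nM in this assay, at which 1 of the 3 values shown sits, marks how far outside the measured range it lies.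

Compound 4 `O=c1[nH]c(=O)n([C@H]2C[C@H](O)[C@@H](CO)O2)cc1-c1cnnn1-c1ccc(Oc2ccccc2)cc1` keeps the triazole arrangement of compound 3 and differs by phenoxy in place of isopropyl on an aromatic carbon. Within the data shown here, no measured step bears directly on this change. Among the measured compounds shown here, the only guide is the starting point: compound 3 sits at the limit, and the swap of one phenyl substituent for another offers no evidence of a rescue, so no step beyond the scatter is expected, meaning an at least 1.3-fold lower number from compound 3 to compound 4 (0.12 log units; that floor lies within the scatter). Compound 4 is therefore estimated at 150000 nM, within a range of 30000 nM to 400000 nM, with a substantial chance that this assay again returns only a limit.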

Compound 4, half-maximal inhibitory concentration: 107000 nM
Compound 4: the middle estimate sits 1.4-fold (0.15 log units) above what was measured, and the stated range covers the measured number.
By their numbers in this assay, from the lowest: compound 1; then compound 2; then compound 4. At a limit, above all of these: compound 3.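

In this assay the change from isopropyl to phenoxy on the aromatic carbon gives an at least 1.8-fold lower number from compound 3 to compound 4 (0.27 log units; that floor lies within the scatter). Compound 4 returns a measured number, 107000 nM, which shows that this triazole arrangement can give a value inside the measured range, something compound 3 alone did not show. The value of compound 3 is a limit and not a number, so the step has only a floor, and its true size stays unknown: the limit of > 200000 nM in this assay, at which 1 of the 4 values shown sits.

The compounds shown leave open whether an amine or a carboxylic acid at this same place would move the number further, and whether phenoxy would change the number in the triazole arrangement of compound 2. Nor do they separate the oxygen of phenoxy from its ring, as a methoxy group at that place could.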